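Methylsulfanyl for Methyl on a Nucleoside Sugar Ring

A few compounds are considered here, and "the series" means these few. Any claim that something is new, unique, unknown or untested is made for them only; others in the source may bear on it.

Compound 1: `C[C@H]1O[C@@H](n2cnc3c(N)nc(NN)nc32)[C@H](O)[C@@H]1O`, 188000 nM
Compound 2: `CS[C@H]1O[C@@H](n2cnc3c(N)nc(NN)nc32)[C@H](O)[C@@H]1O`, 178000 nM
Compound 3: `CNc1ncnc2c1ncn2[C@@H]1O[C@H](C)[C@@H](O)[C@H]1O`, 266000 nM

Three nucleoside analogues have been measured in an ADME assay on L6 cells (Rattus norvegicus) for cytotoxicity; a higher number here means a weaker inhibitor, a lower number a stronger inhibitor. Compound 1 `C[C@H]1O[C@@H](n2cnc3c(N)nc(NN)nc32)[C@H](O)[C@@H]1O` gives 188000 nM in this assay. Compound 2 `CS[C@H]1O[C@@H](n2cnc3c(N)nc(NN)nc32)[C@H](O)[C@@H]1O`, which carries methylsulfanyl in place of methyl on a saturated ring carbon, gives 178000 nM in this assay. The step between these two is a 1.1-fold lower number from compound 1 to compound 2 (0.02 log units; within the scatter), so the exchange of the methyl for the methylsulfanyl group left the read-out essentially unchanged here.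

Compound 3 `CNc1ncnc2c1ncn2[C@@H]1O[C@H](C)[C@@H](O)[C@H]1O` has a different core from compound 1; the difference between the two cores is not broken down here. In this assay compound 3 gives 266000 nM, a number within the scatter of both compound 1 and compound 2.

Compound 4 `CNc1ncnc2c1ncn2[C@@H]1O[C@H](SC)[C@@H](O)[C@H]1O` has not yet been measured in this assay. It relates to compound 3 as compound 2 relates to compound 1: the change is methylsulfanyl in place of methyl on a saturated ring carbon, in the same place on the sugar ring. Because the earlier step is a 1.1-fold lower number from compound 1 to compound 2 (0.02 log units; within the scatter), compound 4 is expected to sit close to compound 3, with an estimated step of a 1.1-fold lower number from compound 3 to compound 4 (0.03 log units; within the scatter). For compound 4 the estimate in this assay is therefore 250000 nM, expected to fall between 150000 nM and 420000 nM.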

Compound 4, half-maximal inhibitory concentration: 159000 nM
Compound 4: middle estimate off by 1.6-fold (0.20 log units), on the high side, and the stated range covers the measured number.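

In this assay, within the data shown here, putting methylsulfanyl in place of methyl on a saturated ring carbon gives a 1.7-fold lower number from compound 3 to compound 4 (0.22 log units; within the scatter), so on the core of compound 3, as on the core of compound 1, the exchange produces no step that stands clear of the usual scatter. Set side by side, the two steps cannot be told apart: the same change on two cores in this assay, a 1.1-fold lower number (0.02 log units; within the scatter) from compound 1 to compound 2 and a 1.7-fold lower number (0.22 log units; within the scatter) from compound 3 to compound 4, 1.6-fold (0.20 log units) apart, within the scatter of two such steps. This shows that, across these two pairs, the change carries from one core to the other without a distinct effect on the read-out, but it does not show that the two cores respond identically, since steps this small could hide a modest real difference, and two pairs say nothing about any third core.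

The compounds shown leave open whether other groups on the same saturated ring carbon, such as an ethylsulfanyl, a hydroxymethyl or an amine, would also leave the read-out where methyl and methylsulfanyl leave it. They also leave open whether the exchange stays this small on a core with a different group in place of the methylamino or the hydrazinyl, and whether any of this holds beyond this assay.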